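Swapping methoxy for trifluoromethyl on the aryl ether

The compounds below may be only part of what the source reports. "The series", "measured", "known", "first", "only" and "open" are said of these compounds alone.

Compound 1 `COc1ccccc1OC1CCN(c2ccc(-n3ccnc3)nn2)CC1` gives 543 nM in an assay on microsomes from liver for inhibition of acyl-CoA desaturase 1 (Rattus norvegicus) (on this read-out lower numbers stand for stronger inhibition and higher numbers for weaker inhibition), the highest of the three numbers measured. Compound 2 `Cc1cccc(OC2CCN(c3ccc(-n4ccnc4)nn3)CC2)c1` gives 251 nM and compound 3 `c1cn(-c2ccc(N3CCC(Oc4ccc5c(c4)CCC5)CC3)nn2)cn1` gives 62 nM; both steps away from compound 1 lie beyond the scatter, a 2.2-fold lower number from compound 1 to compound 2 (0.34 log units; beyond the scatter) and an 8.8-fold lower number from compound 1 to compound 3 (0.94 log units; beyond the scatter), and a 4.0-fold lower number from compound 2 to compound 3 (0.61 log units; beyond the scatter). All three measured steps change the aryl group on the ether oxygen, as does compound 4 `FC(F)(F)c1ccccc1OC1CCN(c2ccc(-n3ccnc3)nn2)CC1`, which differs from compound 1 by trifluoromethyl in place of methoxy on an aromatic carbon ortho to a large group. For the measured compounds named here, no measured step exchanges a methoxy for a trifluoromethyl, so the prior steps show only that aryl changes here move the number modestly. Compound 4 is therefore expected at a modestly lower number, a 1.8-fold lower number from compound 1 to compound 4 (0.26 log units; within the scatter), estimated at 300 nM within 100 nM to 900 nM.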

Compound 4, half-maximal inhibitory concentration: 4 nM
Compound 4: the middle estimate sits 75-fold (1.88 log units) above what was measured; the whole stated range lies above it.
By their numbers in this assay, from the lowest: compound 4; then compound 3; then compound 2; then compound 1.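

In this assay, for the compounds shown here, the group on this aromatic carbon, ortho to a large group, matters far more than the earlier aryl changes suggested: a 140-fold lower number from compound 1 to compound 4 (2.13 log units; beyond the scatter) is a large step, whereas all the earlier steps were modest. The change leaves the rest of compound 1 untouched, replacing methoxy, with one hydrogen-bond acceptor, by trifluoromethyl, with none. Nothing available explains the size of this step.

The compounds shown leave open whether chlorine or an ethyl group on the same carbon would give a similar step. They also leave open whether trifluoromethyl would do so on the 2,3-dihydro-1H-inden-5-yl group of compound 3.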